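Morpholine for Thiomorpholine in Pyridyl Thiosemicarbazide Analogues

The source may report more compounds than this note shows. Statements on the series, on what has been measured and on what is new or still open speak of the compounds shown alone.

compound 1 `Cc1ccnc(/C(N)=N/NC(=S)N2CCOCC2)c1`: 39.1%
compound 2 `Cc1cccc(/C(N)=N/NC(=S)N2CCSCC2)n1`: 46.5%
compound 3 `Cc1ccnc(/C(N)=N/NC(=S)N2CCSCC2)c1`: 41.1%

Of the compounds shown here, three have been tested in a functional assay on HeLa cells (Homo sapiens) for cytotoxicity, read by MTT assay, with a stated time of 72 h, tested at 1 uM; a lower number here means less inhibition of growth, a higher number more inhibition of growth at the concentration tested. In this assay compound 2 gives the highest of the three numbers, but its gaps to compound 3 and to compound 1 are both within the usual scatter, so no order among them can be claimed. Compound 3 and compound 1 share a core and differ by morpholin-4-yl in place of thiomorpholin-4-yl on a thiocarbonyl carbon; this change gave a number 2 percentage points lower from compound 3 to compound 1 (within the scatter). Compound 4 `Cc1cccc(/C(N)=N/NC(=S)N2CCOCC2)n1` has not yet been measured and differs from compound 2 by the same change, (morpholin-4-yl in place of thiomorpholin-4-yl on a thiocarbonyl carbon). The core of compound 2 and the core of compound 3 contain the same atoms joined differently; the difference between the two cores is not broken down here. Given that the one measured instance of this change, a number 2 percentage points lower from compound 3 to compound 1 (within the scatter), lay within the scatter, the step for compound 4 is expected to be a number 2 percentage points lower from compound 2 to compound 4 (within the scatter). Compound 4 is therefore estimated at 44.5%, with a range from 34% to 55%.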

Compound 4, percent growth inhibition at one concentration: 25.7%
The estimate for compound 4 lay 18.8 percentage points above the measured number; measured number below the stated range.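

In this assay, morpholin-4-yl in place of thiomorpholin-4-yl on a thiocarbonyl carbon gave a number 20.8 percentage points lower from compound 2 to compound 4 (beyond the scatter), so the step seen on one core did not carry over to the other: the same change on two cores in this assay, a number 2 percentage points lower (within the scatter) from compound 3 to compound 1 and a number 20.8 percentage points lower (beyond the scatter) from compound 2 to compound 4, 18.8 percentage points apart, beyond the scatter of two such steps. Among the compounds shown here, in these two pairs, then, the size of the step depends on the core, and the step on one core was no guide to the step on the other. For the compounds shown here, with only one pair for each core, the data do not show why the two cores part or how the change would behave on a further core.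

The compounds shown leave open how a piperidin-1-yl or 4-methylpiperazin-1-yl group on the thiocarbonyl carbon would compare on either core. Going by these compounds, an open-chain dimethylamino group at that place also remains open.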